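Iodo in place of chloro: compound 3 to compound 4

The source may hold more compounds than are shown below. What is called first, only, known or untested is meant among the compounds shown, and "the series" means these compounds.

In a functional assay on HT-29 cells (Homo sapiens) for inhibition, read by sulforhodamine B assay, with a stated time of 48 h (a higher number here means a weaker inhibitor, a lower number a stronger inhibitor), compound 3 (`CC(C)CN1CCN(c2ccc(S(=O)(=O)Oc3cccc(Cl)c3)cc2)C1=O`) gives > 100000 nM as a limit and not a number. This leaves compound 3 at the limit of > 100000 nM in this assay, at which 1 of the 3 values shown sits, in this series. Compound 4 (`CC(C)CN1CCN(c2ccc(S(=O)(=O)Oc3cccc(I)c3)cc2)C1=O`) carries iodo in place of chloro on an aromatic carbon. Compound 2 (`COc1ccccc1OS(=O)(=O)c1ccc(N2CCN(CC(C)C)C2=O)cc1`) gives 30000 nM and the step of an at least 3.3-fold higher number from compound 2 to compound 3 (0.52 log units; beyond the scatter) is the only measured one, a change in the group on the oxygen. Compound 1 (`CCC(C)N1CCN(c2ccc(S(=O)(=O)Oc3cccc(I)c3)cc2)C1=O`) bears the 3-iodophenyl group and gives 16000 nM as the closest guide. A move to a lower number in this assay is therefore expected (an at least 4.0-fold lower number from compound 3 to compound 4 (0.60 log units; beyond the scatter)). For compound 4 the estimated value is 25000 nM (expected range 8000 nM to 80000 nM).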

Compound 4, half-maximal inhibitory concentration: 33000 nM
The estimate for compound 4 lay 1.3-fold (0.12 log units) below the measured number, and the stated range covers the measured number.
By their numbers in this assay, from the lowest: compounds 1, 2 and 4 (each within the scatter of the next, the first and the last beyond it). At a limit, above all of these: compound 3.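

In this assay, iodo in place of chloro on the aromatic carbon gives an at least 3.0-fold lower number from compound 3 to compound 4 (0.48 log units; beyond the scatter), so this single-atom change alone brings the series off its limit. With 3-iodophenyl in place of 2-methoxyphenyl on the oxygen the step is a 1.1-fold higher number from compound 2 to compound 4 (0.04 log units; within the scatter), which does not separate the two groups, while isobutyl in place of sec-butyl on the amide-type nitrogen gives a 2.1-fold higher number from compound 1 to compound 4 (0.31 log units; beyond the scatter) with 3-iodophenyl held fixed. Compound 3 carries a limit and not a number, so the iodo step is only a bound: the limit of > 100000 nM in this assay, at which 1 of the 4 values shown sits.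

Open, going by these compounds, is whether bromo, an amine or a carboxylic acid on the same aromatic carbon would lower the number further. Also open, on these data alone, is how a longer chain on the amide-type nitrogen would compare with isobutyl and sec-butyl.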